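The source may report more compounds than this note shows. Statements on the series, on what has been measured and on what is new or still open speak of the compounds shown alone.

Of the compounds shown here, two have been measured. Compound 1, `Cn1c([C@@H]2O[C@H](COP(=O)(O)OP(=O)(O)OP(=O)(O)O)[C@@H](O)[C@H]2O)nc2ccccc21`, gives 200 nM in a functional assay for agonist activity at P2Y purinoceptor 2 (Homo sapiens), read by FLIPR; on this read-out lower numbers stand for an effect already at smaller amounts and higher numbers for an effect only at larger amounts of compound. Compound 2, `COc1cccc2sc([C@@H]3O[C@H](COP(=O)(O)OP(=O)(O)OP(=O)(O)O)[C@@H](O)[C@H]3O)nc12`, gives 700 nM in this assay and therefore stands at the higher of the two numbers, the gap to compound 1 lying beyond the usual scatter of the measurement. Compound 3, `O=P(O)(O)OP(=O)(O)OP(=O)(O)OC[C@H]1O[C@@H](c2nc3ccccc3s2)[C@H](O)[C@@H]1O`, has not yet been measured in this assay. It differs from compound 2 in a single place: hydrogen in place of methoxy on an aromatic carbon. Among the compounds with values here, no measured pair in this set shows what removing a methoxy from an aromatic carbon does here, so the direction of the step is not fixed by the data. Compound 2 and compound 1 share a triphosphate-bearing sugar and differ only in the aromatic part, and compound 3 brings the aromatic part closer to the size of compound 1. On that basis compound 3 is expected to give a number near that of compound 2 or somewhat lower, with the step estimated as a 1.4-fold lower number from compound 2 to compound 3 (0.15 log units; within the scatter). For compound 3 in this assay the estimate is 500 nM, with a range from 150 nM to 2000 nM.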

Compound 3, half-maximal effective concentration: 22 nM
Estimate against measurement, compound 3: 23-fold (1.36 log units) above, and the stated range ends above it.
By their numbers in this assay, from the lowest: compound 3; then compound 1; then compound 2.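

In this assay, the methoxy on an aromatic carbon of the six-membered aromatic ring proves to be far from a neutral feature: hydrogen in its place gives a 32-fold lower number from compound 2 to compound 3 (1.50 log units; beyond the scatter) and turns a compound with the highest number of the set into the one with the lowest. The same result shows that the 1-methyl-1H-benzimidazol-2-yl group of compound 1 does not mark the lowest number reached in this series, since 1,3-benzothiazol-2-yl in its place on a saturated ring carbon gives a 9.1-fold lower number from compound 1 to compound 3 (0.96 log units; beyond the scatter) with the rest of the molecule unchanged. Nothing available here accounts for the size of either step.

The compounds shown leave open whether this large step is particular to methoxy or would also be seen with a fluorine, a hydroxyl or an ethoxy at the same aromatic carbon, since only methoxy and hydrogen have been compared there. They also leave open whether a methoxy at another carbon of that ring, or on the aromatic part of compound 1, would carry a similar penalty.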